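This account rests on a few compounds, and the source may have more. Where it says the series, first, only, none or still open, it means among the compounds named here.

Compound 1 `Clc1ccc(Cn2c(Cl)nc3cc(Cl)c(Cl)cc32)cc1` and compound 2 `Clc1ccc(Cn2c(Br)nc3cc(Cl)c(Cl)cc32)cc1` share one core and differ only in bromo in place of chloro on an aromatic carbon. In a functional assay on KB cells (Homo sapiens) for inhibition (a higher number here means a weaker inhibitor, a lower number a stronger inhibitor), compound 1 gives no number, only a limit of the assay, > 100000 nM. In this assay compound 2 likewise gives only a limit, > 100000 nM. The step between them, a step that the two limits leave unreadable from compound 1 to compound 2, accordingly has no readable size. Both values sit at the same limit, (the limit of > 100000 nM in this assay, at which 2 of the 2 values shown sit), so compound 2 stands at the limit of this assay with no number of its own.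

Compound 3 `FC(F)(F)c1ccc(Cn2c(Br)nc3cc(Cl)c(Cl)cc32)cc1` has not yet been measured. It differs from compound 2 by trifluoromethyl in place of chloro on an aromatic carbon. Among the compounds with values here, no measured step bears directly on this change, and the only measured step, a step that the two limits leave unreadable from compound 1 to compound 2, is itself unreadable, since neither compound 1 nor compound 2 gives a number below the limit. With no inhibition seen for compound 1 or compound 2, compound 3 is expected to remain at or near the limit in this assay. The step that the limit leaves unreadable from compound 2 to compound 3 is expected to be none beyond the scatter. The estimate for compound 3 in this assay is 150000 nM, within a range from 30000 nM to 1000000 nM.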

Compound 3, half-maximal inhibitory concentration: > 100000 nM
Compound 3 was reported as a limit (the forecaster's own chance of this, stated with the estimate: 85%); the middle value does not contradict the limit.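

Within the data shown here, compound 3, like compound 2, gives only a limit of the assay in this assay, so no step between these two compounds can be read, and the same holds for compound 1: the limit of > 100000 nM in this assay, at which 3 of the 3 values shown sit.

The compounds shown leave open whether any change on the shared core brings a value under that limit in this assay.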